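This account rests on a few compounds, and the source may have more. Where it says the series, first, only, none or still open, it means among the compounds named here.

For the measured compounds named here, in a functional assay on HCC827 cells (Homo sapiens) for inhibition, read by fluorescence, with a stated time of 72 h (on this read-out higher numbers stand for weaker inhibition of growth and lower numbers for stronger inhibition of growth), compound 2 (`CCCCCCn1cnc2c(Nc3ccc(O)cc3)nc(N[C@H]3CC[C@H](N)CC3)nc21`) gives 24700 nM as the highest of three numbers so far, against compound 1 (`N[C@H]1CC[C@H](Nc2nc(Nc3ccc(Cl)cc3)c3ncn(C4CCCCC4)c3n2)CC1`) at 9100 nM and compound 3 (`CCCCCCn1cnc2c(Nc3cccc(Cl)c3)nc(N[C@H]3CC[C@H](N)CC3)nc21`) at 10200 nM in the same test. Compound 4 (`N[C@H]1CC[C@H](Nc2nc(Nc3ccc(O)cc3)c3ncn(C4CCCCC4)c3n2)CC1`) keeps the 4-hydroxyphenyl group of compound 2 and changes in one place, with cyclohexyl in place of hexyl on an aromatic nitrogen. Going by the values given here, no measured step makes this swap on its own. Among the compounds with values here, the only step available is a 2.4-fold lower number from compound 2 to compound 3 (0.38 log units; beyond the scatter) and it concerns the other group, so it says little here. A weak hint comes from two compounds that differ in more than one place. Compound 1 with cyclohexyl gives 9100 nM and compound 3 with hexyl gives 10200 nM and these two values lie within the scatter of each other. No step beyond the scatter is therefore expected in this assay and the estimated change is just a 1.2-fold lower number from compound 2 to compound 4 (0.09 log units; within the scatter) in size. Compound 4 is expected at 20000 nM with 8000 nM to 45000 nM as the estimated range.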

Compound 4, concentration for 50% growth inhibition: 32500 nM
For compound 4 the middle estimate is 1.6-fold (0.21 log units) below the measured one; measured number inside the range.
By their numbers in this assay, from the lowest: compounds 1 and 3 (each within the scatter of the next); then compounds 2 and 4 (each within the scatter of the next).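

In this assay, replacing the open hexyl chain on the aromatic nitrogen with a cyclohexyl ring gives a change that stays within the scatter (a 1.3-fold higher number from compound 2 to compound 4 (0.12 log units; within the scatter)), so with the 4-hydroxyphenyl group in place, this read-out does not separate the chain from the ring. With cyclohexyl held fixed, hydroxy in place of chloro on the aromatic carbon does give a change beyond the scatter (a 3.6-fold higher number from compound 1 to compound 4 (0.55 log units; beyond the scatter)), so this second change registers where the first does not. No measurement here offers a reason for either result.

As far as these compounds go, only hexyl and cyclohexyl are seen on this nitrogen, so it remains open whether a much shorter chain such as ethyl, or a chain ending in an amine, would also leave the number unmoved. From the compounds shown here alone, it is also open whether a carboxylic acid or a methoxy group in place of chloro or hydroxy on the aromatic carbon would shift the number further.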